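This account rests on a few compounds, and the source may have more. Where it says the series, first, only, none or still open, it means among the compounds named here.

In an ADME assay on RAW264.7 cells (Mus musculus) for cytotoxicity, read by MTT assay, with a stated time of 24 h, in the absence of a further agent (on this read-out lower numbers stand for stronger inhibition and higher numbers for weaker inhibition), compound 3 (`COCCCCOc1ccc(C(O)C2OC(=O)c3c(OC)cc(OC)cc32)cc1`) gives > 40000 nM as a limit and not a number. Compound 1 (`CCOc1ccc(C(O)C2OC(=O)c3c(OC)cc(OC)cc32)cc1`) gives > 40000 nM as a limit too. Compound 2 (`CCCOc1ccc(C(O)C2OC(=O)c3c(OC)cc(OC)cc32)cc1`) also gives > 40000 nM as a limit. Compound 3 thus stands with the others at the limit of > 40000 nM in this assay, at which 3 of the 3 values shown sit, and no finer ranking is possible. Compound 4 (`COc1cc(OC)c2c(c1)C(C(O)c1ccc(OCc3ccc(F)cc3)cc1)OC2=O`) differs from compound 3 in one place: 4-fluorophenyl in place of 3-methoxypropyl on a saturated chain carbon bound to an oxygen on an aromatic ring. Cut one bond further out, 4-methoxybutyl gives way to 4-fluorobenzyl. The steps a step that the two limits leave unreadable from compound 1 to compound 2 and a step that the two limits leave unreadable from compound 1 to compound 3 and a step that the two limits leave unreadable from compound 2 to compound 3 all changed this same chain, but their size cannot be read, so no change beyond the usual scatter is expected in either direction. The expected step is a number no higher from compound 3 to compound 4 (the limit leaves the size open) and it remains uncertain, as none of these compounds carries a ring on this chain. For compound 4 the estimate is 40000 nM with an expected range from 15000 nM to 80000 nM in this assay here.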

Compound 4, half-maximal inhibitory concentration: > 40000 nM
Compound 4: only a limit was reported; the forecaster's own chance of this, stated with the estimate: 75%; the middle value sits exactly at the limit.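

In this assay compound 4 gives > 40000 nM as a limit and not a number. The steps to compound 4 from compound 1, compound 2 and compound 3 therefore cannot be read: the limit of > 40000 nM in this assay, at which 4 of the 4 values shown sit.

Going by these compounds, whether changing this chain alters cytotoxicity at all remains open.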